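Thiophenyl for benzylamino at the aminoquinoxaline core

This account rests on a few compounds, and the source may have more. Where it says the series, first, only, none or still open, it means among the compounds named here.

Measured so far:
Compound 1, `COc1cc(CNc2nc3cc(N)cc(N)c3nc2-c2ccccc2)cc(OC)c1OC`: 6310 nM
Compound 2, `Nc1cc(N)c2nc(-c3ccccc3)c(NCc3ccc(F)cc3)nc2c1`: 3160 nM
Compound 3, `COc1ccc(CNc2nc3cc(N)cc(N)c3nc2-c2ccccc2)cc1`: 26300 nM

All three share one core and differ only in the group on the ring carbon bearing the benzylamino chain. Read-out is a functional assay on U-251 cells (Homo sapiens) for inhibition, read by sulforhodamine B assay, with a stated time of 48 h; a lower number here means a stronger inhibitor of growth, a higher number a weaker inhibitor of growth. Compound 2 gives the lowest number of the three, but compound 1 lies within the usual scatter of it, so the two cannot be told apart. Within the data shown here, compound 3 lies beyond the scatter: an 8.3-fold higher number from compound 2 to compound 3 (0.92 log units; beyond the scatter), the only one-point step among the measured compounds.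

Compound 4, `Nc1cc(N)c2nc(-c3ccccc3)c(Sc3ccc(F)cc3)nc2c1`, is the next step from compound 2. The change is (4-fluorophenyl)sulfanyl in place of (4-fluorobenzyl)amino on an aromatic carbon. No measured step touches the linker between the core and the fluorophenyl ring; the one step shown changes only the para substituent of that ring. From the compounds shown here alone, the measured set therefore gives no direct guide to the size or direction of this change, and the loss of the hydrogen-bond donor and one heavy atom of the chain is untested here.

Among the measured compounds shown here, with no bearing step, the estimate is anchored on compound 2 and widened. Compound 4 is expected to fall near 7900 nM, with a range from 2500 nM to 25000 nM. This estimate corresponds to an expected step of a 2.5-fold higher number from compound 2 to compound 4 (0.40 log units; beyond the scatter), leaning toward a weaker inhibitor of growth but not confidently beyond the scatter.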

Compound 4, concentration for total growth inhibition: 31600 nM
For compound 4 the middle estimate is 4.0-fold (0.60 log units) below the measured one; the measured number lies above the stated range.
By their numbers in this assay, from the lowest: compounds 2 and 1 (each within the scatter of the next); then compounds 3 and 4 (each within the scatter of the next).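

In this assay, among these compounds, this is the first reading of a change to the link between the shared core and the fluorophenyl ring, rather than to a substituent on that ring as in an 8.3-fold higher number from compound 2 to compound 3 (0.92 log units; beyond the scatter): (4-fluorophenyl)sulfanyl in place of (4-fluorobenzyl)amino gives a 10-fold higher number from compound 2 to compound 4 (1.00 log units; beyond the scatter), on the aromatic carbon next to the ring nitrogen and ortho to a phenyl group. The position therefore responds to the link as well as to the ring substituent, and in the direction of a weaker inhibitor of growth. The change swaps 1 hydrogen-bond donor for 0 hydrogen-bond donors and 9 heavy atoms for 8, and nitrogen for sulfur, all in a single step, and nothing available explains the rise in the number.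

Still open, from the compounds shown here alone, is which of these differences carries the step: a (4-fluorobenzyl)sulfanyl group would keep the chain of compound 2 with sulfur in the link, and a (4-fluorophenyl)amino group would keep the nitrogen on the shorter chain of compound 4. Also open, going by these compounds, is whether methoxy in place of fluoro on the ring behaves the same way with a sulfanyl link.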